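An Aryl Exchange Among Closely Matched Compounds

This account rests on a few compounds, and the source may have more. Where it says the series, first, only, none or still open, it means among the compounds named here.

In a functional assay on K562 cells (Homo sapiens) for inhibition, read by fluorescence, with a stated time of 72 h (on this read-out lower numbers stand for stronger inhibition of growth and higher numbers for weaker inhibition of growth), compound 1 `CCCCCCn1cnc2c(Nc3cccc(Cl)c3)nc(N[C@H]3CC[C@H](N)CC3)nc21` gives 2300 nM, compound 2 `CC(C)CCn1cnc2c(Nc3cccc(Cl)c3)nc(N[C@H]3CC[C@H](N)CC3)nc21` gives 1500 nM and compound 3 `CCCCn1cnc2c(Nc3cc(OC)cc(OC)c3)nc(N[C@H]3CC[C@H](N)CC3)nc21` gives 2400 nM. These three numbers lie within the scatter of one another, so compound 3 stands level with the other two.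

Compound 4 `CCCCn1cnc2c(Nc3cccc(Cl)c3)nc(N[C@H]3CC[C@H](N)CC3)nc21` carries 3-chlorophenyl in place of 3,5-dimethoxyphenyl on a nitrogen on an aromatic ring. It keeps the chain of compound 3 and takes the 3-chlorophenyl found in compound 1 and compound 2. Among the compounds with values here, no measured step isolates this exchange. Within the data shown here, the only measured step, a 1.5-fold lower number from compound 1 to compound 2 (0.19 log units; within the scatter), alters the chain instead, so it bears on the exchange only indirectly: among compounds with 3-chlorophenyl, that chain change stayed within the scatter. A change beyond the scatter is therefore not expected in this assay. The expected step is a 1.3-fold lower number from compound 3 to compound 4 (0.10 log units; within the scatter). Compound 4 is estimated at 1900 nM, with an expected range of 900 nM to 4000 nM.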

Compound 4, concentration for 50% growth inhibition: 2000 nM
For compound 4 the middle estimate is 1.1-fold (0.02 log units) below the measured one, and the stated range covers the measured number.
By their numbers in this assay, from the lowest: compounds 2, 4, 1 and 3 (each within the scatter of the next).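

The exchange is now isolated on a single chain, and this assay gives a 1.2-fold lower number from compound 3 to compound 4 (0.08 log units; within the scatter) for 3-chlorophenyl in place of 3,5-dimethoxyphenyl, so on this nitrogen the two aryl groups stand level despite their different substituents. With 3-chlorophenyl held fixed, compound 4 also links the chain variants, with a 1.3-fold higher number from compound 2 to compound 4 (0.12 log units; within the scatter) and a 1.2-fold lower number from compound 1 to compound 4 (0.06 log units; within the scatter), so all three chains shown stand level as well. No measured evidence here bears on why these changes leave the number level.

From the compounds shown here alone, whether any aryl group on this nitrogen can move the number beyond the scatter stays open, for instance a phenyl carrying a carboxylic acid or an amine, or a pyridine ring. Also open, going by these compounds, is whether a much shorter chain, such as ethyl, would stay level with these compounds.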